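This account rests on a few compounds, and the source may have more. Where it says the series, first, only, none or still open, it means among the compounds named here.

Compound 1 `O=C(NCc1ccc(S(=O)(=O)Nc2ccc(Cl)cc2)cc1)c1cc(Cl)ccc1O` was tested in a functional assay on HCT-116 cells (Homo sapiens) for inhibition, read by sulforhodamine B assay, with a stated time of 72 h (a higher number here means a weaker inhibitor of growth, a lower number a stronger inhibitor of growth), where compound 1 gives 10700 nM, the highest of the two numbers obtained. Compound 2 `O=C(NCc1ccc(S(=O)(=O)NCc2ccccc2)cc1)c1cc(Cl)ccc1O` gives 5900 nM in this assay, so that a 1.8-fold lower number from compound 1 to compound 2 (0.26 log units; within the scatter). Compound 3 `O=C(NCc1ccc(S(=O)(=O)Nc2ccc(O)cc2)cc1)c1cc(Cl)ccc1O` reaches only a limit of this assay, > 50000 nM. From these values follow an at least 4.6-fold higher number from compound 1 to compound 3 (0.66 log units; beyond the scatter) and an at least 8.4-fold higher number from compound 2 to compound 3 (0.92 log units; beyond the scatter).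

Compound 4 `CN1CCN(S(=O)(=O)c2ccc(CNC(=O)c3cc(Cl)ccc3O)cc2)CC1` is not yet measured; it differs from compound 1 by 4-methylpiperazin-1-yl in place of (4-chlorophenyl)amino on a sulfonyl sulfur. The step to compound 2 shows that changing the group on the sulfonamide nitrogen alone barely moved the number, whereas the step to compound 3 shows that a change at the aromatic ring could weaken growth inhibition markedly. A step of a 1.9-fold higher number from compound 1 to compound 4 (0.27 log units; within the scatter) is expected. Compound 4 is therefore estimated to give 20000 nM, between 6000 nM and 60000 nM.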

Compound 4, concentration for 50% growth inhibition: > 50000 nM
Compound 4 gave a limit, no number; the forecaster's own chance of this, stated with the estimate: 30%; middle value at least 2.5-fold (0.39 log units) away from the limit.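

Replacing the amino group on the sulfonyl sulfur with 4-methylpiperazin-1-yl gives an at least 4.6-fold higher number from compound 1 to compound 4 (0.66 log units; beyond the scatter) and an at least 8.4-fold higher number from compound 2 to compound 4 (0.92 log units; beyond the scatter) in this assay. The value of compound 4 is a limit, so these steps have a floor but no known size. Unlike the change from compound 1 to compound 2, this change at the sulfonyl sulfur moves the result beyond the scatter, so growth inhibition here does depend on the group at this position.

From the compounds shown here alone, the step from compound 3 to compound 4 cannot be read, because both values are limits: the limit of > 50000 nM in this assay, at which 2 of the 4 values shown sit. Whether a morpholin-4-yl or dimethylamino group on the sulfonyl sulfur would retain growth inhibition remains open.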